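A few compounds are considered here, and "the series" means these few. Any claim that something is new, unique, unknown or untested is made for them only; others in the source may bear on it.

Working notes on the series, read in a functional assay on MCF7 cells (Homo sapiens) for cytotoxicity, read by MTT assay, with a stated time of 96 h; a lower number here means a stronger inhibitor, a higher number a weaker inhibitor. Among the measured compounds shown here, compound 1 (`COc1cc(C(=O)c2cn(-c3ccccc3)cc2-c2ccccc2Cl)cc(OC)c1OC`) gives 76 nM, and compound 2 (`COc1cc(C(=O)c2cn(-c3ccccc3)cc2-c2ccc([N+](=O)[O-])cc2)cc(OC)c1OC`) gives 590 nM, the higher of the two numbers so far. For the measured compounds named here, the only measured step, a swap of 2-chlorophenyl for 4-nitrophenyl, is a 7.8-fold higher number from compound 1 to compound 2 (0.89 log units; beyond the scatter). Compound 3 (`COc1ccc(-c2cn(-c3ccccc3)cc2C(=O)c2cc(OC)c(OC)c(OC)c2)cc1`) is not yet measured and differs from compound 2 in one place: methoxy in place of nitro on an aromatic carbon. In words, this is methoxy in place of nitro on an aromatic carbon, para to a large group, so 4-nitrophenyl becomes 4-methoxyphenyl. Going by the values given here, no measured pair tests this exchange directly, so the one step available bears on it only loosely. That step shows that the number in this assay can move by a modest amount when this substituted phenyl group changes. Direction is the weakest part of the reasoning, resting only on compound 2 standing at 590 nM, the high end of a very short series. A modest move to a lower number is therefore expected, no larger than the measured step, and the expected size is a 3.3-fold lower number from compound 2 to compound 3 (0.52 log units; beyond the scatter). The estimate for compound 3 is 180 nM, with an expected range of 50 nM to 600 nM.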

Compound 3, half-maximal inhibitory concentration: 70 nM
For compound 3 the middle estimate is 2.6-fold (0.41 log units) above the measured one, within the range that was stated.
By their numbers in this assay, from the lowest: compounds 3 and 1 (each within the scatter of the next); then compound 2.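

In this assay, the exchange of 4-nitrophenyl for 4-methoxyphenyl gives an 8.4-fold lower number from compound 2 to compound 3 (0.93 log units; beyond the scatter), which shows that a change at this one place on the phenyl ring, with the rest of the core held constant, can by itself produce a modest move beyond the scatter. The step of a 1.1-fold lower number from compound 1 to compound 3 (0.04 log units; within the scatter) lies within the scatter, so 4-methoxyphenyl and 2-chlorophenyl cannot be told apart here, and compound 2 alone stands apart from the other two compounds, with its 4-nitrophenyl group. No measurement available for these compounds accounts for either step.

Since 2-chlorophenyl and 4-methoxyphenyl differ both in the group and in where it sits on the ring, the compounds shown do not separate these two changes. Also open, going by these compounds, is how an amine or a carboxylic acid in place of methoxy at this position would read in this assay, which would show whether the high number of compound 2 is particular to nitro.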